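The source may report more compounds than this note shows. Statements on the series, on what has been measured and on what is new or still open speak of the compounds shown alone.

Compound 1 `Cc1cc(-c2ccccc2)n(/C(N)=N/S(=O)(=O)c2cc(C)c(Cl)cc2SCc2cccc(C(F)(F)F)c2)n1`: in a functional assay on MCF7 cells (Homo sapiens) for cytotoxicity, read by MTT assay, with a stated time of 72 h (on this read-out higher numbers stand for weaker inhibition and lower numbers for stronger inhibition), compound 1 gives 41000 nM.
Compound 2 `Cc1cc(S(=O)(=O)/N=C(\N)n2nccc2-c2ccccc2)c(SCc2ccccc2)cc1Cl`: in this assay compound 2 gives 20000 nM.
Compound 3 `Cc1cc(-c2ccccc2)n(/C(N)=N/S(=O)(=O)c2cc(C)c(Cl)cc2SCc2ccccc2)n1`: in this assay compound 3 gives 15000 nM.

Among these three numbers compound 2 sits in the middle. Its nearest neighbour is compound 3, and that gap is within the scatter, so the two cannot be told apart. Compound 1 gives a higher number than compound 2, and that gap is beyond the scatter.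

Compound 4 `Cc1ccc(CSc2cc(Cl)c(C)cc2S(=O)(=O)/N=C(\N)n2nccc2-c2ccccc2)cc1` is compound 2 with one change: methyl in place of hydrogen on an aromatic carbon.

Within the data shown here, two measured steps bear on this. The closest is a 2.7-fold lower number from compound 1 to compound 3 (0.44 log units; beyond the scatter), where removing a trifluoromethyl group from the benzyl ring lowered the number; read the other way, putting a group onto that ring raised it. The other, a 1.3-fold lower number from compound 2 to compound 3 (0.12 log units; within the scatter), adds a methyl on a different ring and stays within the scatter. A methyl is a smaller group than trifluoromethyl, so the step in this assay is expected to be small, pointing if anywhere toward a higher number. The expected step is a 1.2-fold higher number from compound 2 to compound 4 (0.08 log units; within the scatter). Compound 4 is therefore estimated at 24000 nM, within a range from 10000 nM to 60000 nM.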

Compound 4, half-maximal inhibitory concentration: 21000 nM
For compound 4 the middle estimate is 1.1-fold (0.06 log units) above the measured one, and the stated range covers the measured number.
By their numbers in this assay, from the lowest: compounds 3, 2, 4 and 1 (each within the scatter of the next, the first and the last beyond it).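

In this assay, placing a methyl on the benzyl ring, para to a large group, gives a 1.1-fold higher number from compound 2 to compound 4 (0.02 log units; within the scatter), so the two compounds cannot be told apart. Among these compounds, this is the first view of a methyl on that ring: the only earlier step there, a 2.7-fold lower number from compound 1 to compound 3 (0.44 log units; beyond the scatter), involved trifluoromethyl and lay beyond the scatter, whereas this methyl stays within the scatter, as does the methyl on the other ring in a 1.3-fold lower number from compound 2 to compound 3 (0.12 log units; within the scatter). The two methyl steps therefore agree across the two places tested, but no measurement here gives a reason for the difference from the trifluoromethyl step.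

The compounds shown leave open how far this tolerance extends at the same place on the benzyl ring, since only hydrogen and methyl appear there, and an ethyl, a methoxy group, an amine or a carboxylic acid could each give a different result. They also leave open how trifluoromethyl itself would behave at this exact place. The compounds carrying it and the methyl differ in where the group sits on the ring.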